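This account rests on a few compounds, and the source may have more. Where it says the series, first, only, none or still open, it means among the compounds named here.

The measured compounds:
Compound 1, `O=S(=O)(c1cnc2ccccc2c1)n1cc(C2=CCNCC2)c2ccccc21`, gives 13 nM.
Compound 2, `O=S(=O)(c1cncc2ccccc12)n1cc(C2=CCNCC2)c2ccccc21`, gives 5 nM.

In an assay on HEK293 cells for displacement of a labelled ligand from 5-hydroxytryptamine receptor 6 (Homo sapiens), read by scintillation counting (on this read-out lower numbers stand for stronger inhibition and higher numbers for weaker inhibition), compound 1 holds the higher of the two numbers on record, and the gap between compound 1 and compound 2 is wider than the usual scatter of repeated measurements, so compound 2 is the more potent of the pair. Both share the same core, and only the sulfonyl-bearing bicyclic aryl group sets them apart.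

Compound 3, `O=S(=O)(c1cnc2ccccc2c1)n1cc(C2=CCNCC2)c2cc(Cl)ccc21`, keeps the sulfonyl aryl group of compound 1 and alters the core instead: chloro in place of hydrogen on an aromatic carbon. Going by the values given here, no measured pair in this set isolates such a change, so its effect has to be anticipated rather than read off. A single halogen on the six-membered ring of the core is a small alteration, and the author expects in this assay a step of modest size, if anything toward a lower number, and possibly none beyond the scatter. For compound 3 the estimate is 8 nM, with a range from 3 nM to 30 nM. That estimate corresponds to an expected step of a 1.6-fold lower number from compound 1 to compound 3 (0.21 log units; within the scatter).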

Compound 3, inhibition constant: 11 nM
The estimate for compound 3 lay 1.4-fold (0.14 log units) below the measured number, within the range that was stated.
By their numbers in this assay, from the lowest: compound 2; then compounds 3 and 1 (each within the scatter of the next).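

In this assay, chloro in place of hydrogen on an aromatic carbon of the core gives a 1.2-fold lower number from compound 1 to compound 3 (0.07 log units; within the scatter), so at this position, meta to a fused ring and para to a fused ring, the read-out does not separate the two compounds. Compounds 1 and 2 differ only in the sulfonyl-bearing bicyclic aryl group and say nothing about the core, whereas this pair shows that, with the sulfonyl aryl group of compound 1 in place, a chlorine atom can occupy this carbon while the number stays within the scatter of the parent. No measurement at hand accounts for the size of this step.

From the compounds shown here alone, it remains open whether a fluoro atom, a methoxy group or a primary amine on this same carbon would give a step beyond the scatter, and whether chloro on the other carbons of that ring would behave as it does here. Going by these compounds, it is also open whether the chloro step would carry over to the sulfonyl aryl group of compound 2, which stands at 5 nM without the chlorine atom.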